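A few compounds are considered here, and "the series" means these few. Any claim that something is new, unique, unknown or untested is made for them only; others in the source may bear on it.

Measured so far in an in vitro functional assay on cells for agonist activity at Bombesin receptor subtype-3 (Mus musculus), read by luminescence and calcium flux; a higher number here means that more compound is needed for the effect, a lower number that less compound is needed:
compound 1, `O=C(O)c1ccccc1-c1ccc(CCc2ncc(CC3CCC3)[nH]2)cc1`, 7.1 nM;
compound 2, `O=C(O)c1ccccc1-c1ccc(CCc2ncc(-c3ccccc3)[nH]2)cc1`, 872 nM;
compound 3, `O=C(O)c1ccccc1-c1ccc(CCc2ncc(Cc3ccc(F)cc3)[nH]2)cc1`, 50 nM.

Compound 3 stands second highest of the three: a 7.0-fold higher number from compound 1 to compound 3 (0.85 log units; beyond the scatter), and a 17-fold lower number from compound 2 to compound 3 (1.24 log units; beyond the scatter). Compound 4 is `O=C(O)c1ccccc1-c1ccc(CCc2ncc(C3CCCCC3)[nH]2)cc1`. The change is cyclohexyl in place of 4-fluorobenzyl on an aromatic carbon. Among the measured compounds shown here, no measured step matches it exactly. Two bear on it in part. a 7.0-fold higher number from compound 1 to compound 3 (0.85 log units; beyond the scatter), where a 4-fluorophenyl replaced a cyclobutyl on a saturated chain carbon, points toward a lower number for a saturated ring. a 17-fold lower number from compound 2 to compound 3 (1.24 log units; beyond the scatter), where 4-fluorobenzyl replaced phenyl on an aromatic carbon, warns that a ring placed on the aromatic carbon itself gave a far higher number. These pull against each other, so the expected step of a 1.7-fold lower number from compound 3 to compound 4 (0.22 log units; within the scatter) is modest and uncertain. Compound 4 is estimated at 30 nM, within 5 nM to 200 nM.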

Compound 4, half-maximal effective concentration: 14.7 nM
Compound 4: the middle estimate sits 2.0-fold (0.31 log units) above what was measured; the range from low to high includes it.
By their numbers in this assay, from the lowest: compound 1; then compound 4; then compound 3; then compound 2.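

In this assay, a ring attached directly to the aromatic carbon is not in itself what gave compound 2 its high number, since cyclohexyl in place of phenyl gives a much lower one (a 59-fold lower number from compound 2 to compound 4 (1.77 log units; beyond the scatter)). Cyclohexyl also improves on 4-fluorobenzyl (a 3.4-fold lower number from compound 3 to compound 4 (0.53 log units; beyond the scatter)), but it does not match cyclobutylmethyl (a 2.1-fold higher number from compound 1 to compound 4 (0.32 log units; beyond the scatter)). Nothing measured here explains these differences. Still open, going by these compounds, is how a cyclopentyl ring, or a piperidine ring with its ring amine, would compare at this position.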